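Adding a methoxy group to compound 3

A few compounds are considered here, and "the series" means these few. Any claim that something is new, unique, unknown or untested is made for them only; others in the source may bear on it.

In a functional assay on SNB-75 cells (Homo sapiens) for inhibition, read by sulforhodamine B assay, with a stated time of 48 h, tested at 10 uM (on this read-out higher numbers stand for more inhibition of growth at the one concentration tested and lower numbers for less inhibition of growth), compound 1 `COc1ccc(-c2nc3sc(-c4ccccc4)cn3n2)cc1` gives 34% and compound 2 `COc1cc(-c2nc3sc(-c4ccccc4)cn3n2)cc(OC)c1OC` gives 24%. Compound 3 `Clc1ccc(-c2cn3nc(-c4ccccc4)nc3s2)cc1` gives 36%, which is within the scatter of compound 1 and higher than compound 2 by more than the scatter. Compound 4 `COc1ccc(-c2nc3sc(-c4ccc(Cl)cc4)cn3n2)cc1` departs from compound 3 by methoxy in place of hydrogen on an aromatic carbon. For the measured compounds named here, no measured pair shows this change alone. Compound 1, which also carries a methoxy group, gives 34% without differing beyond the scatter from compound 3. In this assay the expected change is therefore none beyond the scatter, an estimated a number 2 percentage points higher from compound 3 to compound 4 (within the scatter). For compound 4 the estimated value is 38%, with an expected range of 22% to 54%.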

Compound 4, percent growth inhibition at one concentration: -1.66%
For compound 4 the middle estimate is 39.7 percentage points above the measured one; measured number below the stated range.
By their numbers in this assay, from the lowest: compound 4; then compounds 2, 1 and 3 (each within the scatter of the next, the first and the last beyond it).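

In this assay, methoxy in place of hydrogen on an aromatic carbon, para to a large group, proves far from neutral once compound 3 already carries chloro: the change gives a number 37.7 percentage points lower from compound 3 to compound 4 (beyond the scatter). Chloro in place of hydrogen on compound 1 gives a number 35.7 percentage points lower from compound 1 to compound 4 (beyond the scatter), so within this pair each group removes the inhibition when the other is present. Nothing available explains this loss. On these data alone, whether an amine or a hydroxyl group at the same place would behave like methoxy remains open.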